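From 4-fluoronaphthalen-1-yl to naphthalen-1-yl

This account rests on a few compounds, and the source may have more. Where it says the series, first, only, none or still open, it means among the compounds named here.

Measured in a functional assay on A549 cells (Homo sapiens) for antiproliferative activity, with a stated time of 5 days; on this read-out lower numbers stand for stronger inhibition and higher numbers for weaker inhibition:
- compound 1 `Cc1ccccc1-n1nc(-c2cccc3ccccc23)nc1N1C(=O)COC12C=CC(=O)C=C2`: 130 nM
- compound 2 `O=C1C=CC2(C=C1)OCC(=O)N2c1nc(-c2ccc(F)c3ccccc23)nn1-c1ccccc1`: 320 nM

Compound 2 holds the higher of the two numbers at 320 nM, and compound 1 lies lower at 130 nM, a gap beyond the usual scatter. Compound 3 `O=C1C=CC2(C=C1)OCC(=O)N2c1nc(-c2cccc3ccccc23)nn1-c1ccccc1` is still unmeasured. It differs from compound 2 by hydrogen in place of fluoro on an aromatic carbon. For the measured compounds named here, no measured pair shows this change, so only a small shift toward lower numbers in this assay is expected, none beyond the scatter. The estimated step is a 1.5-fold lower number from compound 2 to compound 3 (0.16 log units; within the scatter). Compound 3 is expected at 220 nM, with an estimated range of 90 nM to 520 nM.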

Compound 3, half-maximal inhibitory concentration: 80 nM
Estimate against measurement, compound 3: 2.8-fold (0.44 log units) above; the whole stated range lies above it.
By their numbers in this assay, from the lowest: compounds 3 and 1 (each within the scatter of the next); then compound 2.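

Hydrogen in place of fluoro, para to a large group on the naphthalene, gives a 4.0-fold lower number from compound 2 to compound 3 (0.60 log units; beyond the scatter) in this assay, so this aromatic carbon is sensitive to the change. Hydrogen in place of methyl on an aromatic carbon gives a 1.6-fold lower number from compound 1 to compound 3 (0.21 log units; within the scatter), so that change shows no shift separable from the scatter. Nothing at hand accounts for the loss carried by the fluoro group.

Going by these compounds, whether chloro, methoxy or an amine on this carbon would read like fluoro or like hydrogen stays open. Also open, on these data alone, is whether the fluoro step holds when the methyl group is present.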